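Lengthening the Side Chain of Compound 2

The compounds below may be only part of what the source reports. "The series", "measured", "known", "first", "only" and "open" are said of these compounds alone.

In a functional assay on A549 cells (Homo sapiens) for antiproliferative activity, read by MTT assay, with a stated time of 48 h (a higher number here means a weaker inhibitor, a lower number a stronger inhibitor), compound 1 `Cn1c(N)c(-c2nc3ccccc3[nH]2)c2nc(C#N)c(C#N)nc21` reaches only a limit, > 50000 nM. Among the measured compounds shown here, compound 2 `CCCn1c(N)c(-c2nc3ccccc3[nH]2)c2nc(C#N)c(C#N)nc21` gives 1970 nM, the only true number so far. Compound 3 `CCN(CC)CCCCn1c(N)c(-c2nc3ccccc3[nH]2)c2nc(C#N)c(C#N)nc21` differs from it by (diethylamino)methyl in place of hydrogen on a saturated chain carbon, three bonds along the chain from an aromatic nitrogen: (diethylamino)methyl in place of hydrogen, turning propyl into 4-(diethylamino)butyl. For the measured compounds named here, one measured step bears on this chain, an at least 25-fold lower number from compound 1 to compound 2 (1.40 log units; beyond the scatter), and it was large. That step added only ethyl, so it is a loose guide to this change. No clear shift beyond the scatter is expected, with an estimated 1.3-fold lower number from compound 2 to compound 3 (0.12 log units; within the scatter). For compound 3 the expected value is 1500 nM, with an estimated range from 300 nM to 8000 nM.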

Compound 3, half-maximal inhibitory concentration: 5750 nM
Estimate against measurement, compound 3: 3.8-fold (0.58 log units) below; the measured number falls inside the stated range.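

In this assay, the gain seen with propyl does not continue along the chain: 4-(diethylamino)butyl gives a 2.9-fold higher number from compound 2 to compound 3 (0.47 log units; beyond the scatter), so this longer, amine-bearing chain makes the inhibitor modestly weaker. Even so, the result still stands clearly on the stronger side of the methyl compound, with an at least 8.6-fold lower number from compound 1 to compound 3 (0.93 log units; beyond the scatter). Compound 1 reaches only a limit, so that step gives a bound and not an exact size: the limit of > 50000 nM in this assay, at which 1 of the 3 values shown sits.

The compounds shown do not separate the effect of chain length from that of the diethylamino group. A plain butyl chain would bear directly on that question.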